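Lengthening the Amide Chain: From Compound 2 to Compound 4

The source may report more compounds than this note shows. Statements on the series, on what has been measured and on what is new or still open speak of the compounds shown alone.

Of the compounds shown here, three sharing one core have been tested in an assay on LtK cells with ATP-sensitive inward rectifier potassium channel 11 (Homo sapiens) as the target; on this read-out higher numbers stand for an effect only at larger amounts of compound and lower numbers for an effect already at smaller amounts. Compound 1 `CC(=O)Nc1c(C(O)(C(F)(F)F)C(F)(F)F)ccc2ccccc12` gives 18 nM, compound 2 `CCC(=O)Nc1c(C(O)(C(F)(F)F)C(F)(F)F)ccc2ccccc12` gives 15 nM, and compound 3 `C/C=C/C(=O)Nc1c(C(O)(C(F)(F)F)C(F)(F)F)ccc2ccccc12` gives 72 nM. Compound 2 cannot be told apart from compound 1, since a 1.2-fold lower number from compound 1 to compound 2 (0.08 log units; within the scatter), but it is clearly separated from compound 3 by a 4.8-fold higher number from compound 2 to compound 3 (0.68 log units; beyond the scatter).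

Compound 4 `CC(C)CCC(=O)Nc1c(C(O)(C(F)(F)F)C(F)(F)F)ccc2ccccc12` is not yet measured. It differs from compound 2 by isopropyl in place of hydrogen on a saturated chain carbon, two bonds along the chain from a carbonyl carbon. Among the compounds with values here, the only measured step that also grows a saturated chain, a 1.2-fold lower number from compound 1 to compound 2 (0.08 log units; within the scatter), stayed within the scatter; the steps of a 4.0-fold higher number from compound 1 to compound 3 (0.60 log units; beyond the scatter) and a 4.8-fold higher number from compound 2 to compound 3 (0.68 log units; beyond the scatter) concern a prop-1-en-1-yl group and bear less directly. A step no larger than the scatter is therefore expected, a 1.5-fold higher number from compound 2 to compound 4 (0.17 log units; within the scatter). For compound 4 the estimate is 22 nM, with a range from 8 nM to 60 nM.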

Compound 4, half-maximal effective concentration: 49 nM
Estimate against measurement, compound 4: 2.2-fold (0.35 log units) below, and the stated range covers the measured number.
By their numbers in this assay, from the lowest: compounds 2 and 1 (each within the scatter of the next); then compounds 4 and 3 (each within the scatter of the next).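

Lengthening the saturated chain is not neutral at this position: isopropyl in place of hydrogen gives (a 3.3-fold higher number from compound 2 to compound 4 (0.51 log units; beyond the scatter)), and isobutyl in place of hydrogen one carbon closer to the carbonyl gives (a 2.7-fold higher number from compound 1 to compound 4 (0.43 log units; beyond the scatter)). The isopentyl and prop-1-en-1-yl amides cannot be told apart (a 1.5-fold lower number from compound 3 to compound 4 (0.17 log units; within the scatter)), so in this assay a saturated chain does not by itself keep the number low. No measured information explains these differences.

As far as these compounds go, whether the unbranched pentyl or butyl chain behaves like isopentyl remains open. So does the effect of an amine or a carboxylic acid at the chain end.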